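Swapping Methyl for Chloro in a Series at the Limit

The source may hold more compounds than are shown below. What is called first, only, known or untested is meant among the compounds shown, and "the series" means these compounds.

Three compounds built on a shared core have been examined in an assay on isolated protein for inhibition of Apoptosis regulator Bcl-2 (Homo sapiens), read by fluorescence polarization; on this read-out higher numbers stand for weaker inhibition and lower numbers for stronger inhibition. Compound 1 `O=C(O)c1ccc(/C=C2\SC(=S)N(c3ccccc3)C2=O)cc1` returns > 10000 nM, which is a limit of the assay and not a number. Compound 2 `COc1ccccc1N1C(=O)/C(=C/c2ccc(OCC(=O)Nc3ccc(C(=O)O)cc3)cc2)SC1=S` gives 10000 nM in this assay. Compound 3 `Cc1ccc(N2C(=O)/C(=C/c3ccc(OCc4ccc(C(=O)O)cc4)cc3)SC2=S)cc1` returns > 10000 nM, again a limit of the assay rather than a measured number. Compound 3 therefore stands at the edge of what this assay can report, and the same is true of compound 1, (the limit of > 10000 nM in this assay, at which 2 of the 3 values shown sit). Going by the values given here, no two of these measured compounds differ in a single place, so there is no measured step to draw on.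

Compound 4 `O=C(O)c1ccc(COc2ccc(/C=C3\SC(=S)N(c4ccc(Cl)cc4)C3=O)cc2)cc1` follows from compound 3 by one change: chloro in place of methyl on an aromatic carbon. Because two of the three values recorded so far sit at the limit, (the limit of > 10000 nM in this assay, at which 2 of the 3 values shown sit), the expected step is a number no higher from compound 3 to compound 4 (the limit leaves the size open), small and with no direction beyond the usual scatter. On that footing compound 4 is estimated at 10000 nM in this assay, with a range from 3000 nM to 30000 nM, and it is quite possible that this assay will once more report only a limit for compound 4.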

Compound 4, inhibition constant: > 10000 nM
Compound 4: a limit, no number (the forecaster's own chance of this, stated with the estimate: 65%); the middle value sits exactly at the limit.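

In this assay compound 4 returns > 10000 nM, a limit of the assay and not a number. Compound 3 also stands at a limit, so no step can be read between compound 3 and compound 4. The compounds shown leave open whether 4-methylphenyl and 4-chlorophenyl differ at all in this read-out, as most values rest at one ceiling: the limit of > 10000 nM in this assay, at which 3 of the 4 values shown sit.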